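This account rests on a few compounds, and the source may have more. Where it says the series, first, only, none or still open, it means among the compounds named here.

The study gathers four compounds built on one shared core, and it measures them in a functional assay on NCI-H1975 cells (Homo sapiens) for antiproliferative activity, read by MTT assay, with a stated time of 72 h; on this read-out lower numbers stand for stronger inhibition and higher numbers for weaker inhibition. Compound 1, `CN1CCN(c2ccc(Nc3ncc4nc(Nc5ccc(F)cc5)n(-c5cccc(NC(=O)CO)c5)c4n3)cc2)CC1`, carries a hydroxyacetamide-bearing phenyl on the core, and in this assay compound 1 gives 580 nM. Compound 2, `CN1CCN(c2ccc(Nc3ncc4nc(Nc5ccc(F)cc5)n(CCNS(=O)(=O)C5CC5)c4n3)cc2)CC1`, has an open-chain cyclopropylsulfonamide ethyl arm in the same region, yet for compound 2 this assay records "not determined" (no result reported). Compound 3, `CNC(=O)CN1CC[C@H](n2c(Nc3ccc(F)cc3)nc3cnc(Nc4ccc(N5CCN(C)CC5)cc4)nc32)C1`, places a pyrrolidine on the core with a (methylcarbamoyl)methyl group on its amine nitrogen, and for compound 3 this assay likewise records "not determined" (no result reported). Compound 3 therefore stands without any number of its own, as does compound 2, so the only measured anchor in the set is compound 1.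

Compound 4, `CN1CCN(c2ccc(Nc3ncc4nc(Nc5ccc(F)cc5)n([C@H]5CCN(S(=O)(=O)C6CC6)C5)c4n3)cc2)CC1`, follows from compound 3 by a single change: cyclopropylsulfonyl in place of (methylcarbamoyl)methyl on an amine nitrogen in a ring. Going by the values given here, no step between measured compounds is available to gauge this change, and with no value for compound 3 the size of the step cannot be derived; the expectation rests on compound 1 alone. Compound 4 is estimated to fall in this assay near 400 nM, within a range from 60 nM to 3000 nM.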

Compound 4, half-maximal inhibitory concentration: 580 nM
Estimate against measurement, compound 4: 1.5-fold (0.16 log units) below; low and high end bracket the measured number.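

Across the measured pair, the substituent on the aromatic nitrogen of the shared core is replaced as a whole: in this assay, putting 1-(cyclopropylsulfonyl)pyrrolidin-3-yl in place of 3-(((hydroxymethyl)carbonyl)amino)phenyl gives no change at the digits printed from compound 1 to compound 4 (within the scatter) in the antiproliferative read-out. Going by these compounds alone, for these two compounds, then, this position carries either the substituted phenyl or the sulfonylated pyrrolidine with the same printed value, which the earlier compounds could not show with only one number among them, while the exchange of (methylcarbamoyl)methyl for cyclopropylsulfonyl on the pyrrolidine amine nitrogen and any step involving compound 2 cannot be read. Nothing available accounts for the two substituents reading alike.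

What the compounds shown leave open is whether the match holds for other groups on the pyrrolidine amine nitrogen, such as an acetyl, a methanesulfonyl or a plain amine hydrogen. Going by these compounds, it is equally open whether a piperidine ring or a longer chain ending in a carboxylic acid on the aromatic nitrogen would keep the value of compound 4 in this assay or move away from it.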